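This account rests on a few compounds, and the source may have more. Where it says the series, first, only, none or still open, it means among the compounds named here.

In a functional assay on MCF7 cells (Homo sapiens) for cytotoxicity, read by MTT assay, with a stated time of 72 h (on this read-out lower numbers stand for stronger inhibition and higher numbers for weaker inhibition), compound 3 `O=[N+]([O-])c1cccc(Nc2nc(SCc3ccc(C(F)(F)F)cc3)nc3ccccc23)c1` reaches only a limit of the assay, at > 50000 nM. Compound 2 `FC(F)(F)c1ccc(CSc2nc(Nc3cccc(C(F)(F)F)c3)c3ccccc3n2)cc1` gives 15300 nM in this assay, and the step of an at least 3.2-fold higher number from compound 2 to compound 3 (0.51 log units; beyond the scatter) runs toward weaker inhibition. Compound 1 `CCCCCCCCCCCCNc1nc(SCc2ccc(C(F)(F)F)cc2)nc2ccccc12` likewise sits at a limit of this assay, at > 50000 nM. Compound 3 thus stands at the weak end of the numbers shown, together with compound 1 and behind compound 2, as far as the limit of > 50000 nM in this assay, at which 2 of the 3 values shown sit, allows one to see.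

Compound 4 `COc1ccc(Nc2nc(SCc3ccc(C(F)(F)F)cc3)nc3ccccc23)cc1OC` differs from compound 3 in one place: 3,4-dimethoxyphenyl in place of 3-nitrophenyl on a nitrogen on an aromatic ring. Among the compounds with values here, no measured step bears directly on this exchange. Within the data shown here, the single measured step, from compound 2 to compound 3, concerns another group on the same nitrogen and shows only that the anilino compounds here spread from a measured number up to the limit. The expected step of an at least 1.6-fold lower number from compound 3 to compound 4 (0.22 log units; that floor lies within the scatter) is therefore toward a somewhat lower number, held with little confidence. Compound 4 is estimated at 30000 nM, within a range from 8000 nM to 100000 nM, with a fair chance that this assay again reports only a limit.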

Compound 4, half-maximal inhibitory concentration: > 50000 nM
Compound 4: no number, only a limit; the forecaster's own chance of this, stated with the estimate: 45%; middle value at least 1.6-fold (0.22 log units) from the limit.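

Within the data shown here, on the nitrogen on an aromatic ring, 3,4-dimethoxyphenyl joins 3-nitrophenyl at the limit of this assay, so 3-(trifluoromethyl)phenyl remains the only aromatic group here that gives a number. Replacing it with 3,4-dimethoxyphenyl gives an at least 3.2-fold higher number from compound 2 to compound 4 (0.51 log units; beyond the scatter), a second exchange of that group that runs toward weaker inhibition. Compound 3 and compound 4 each sit at a limit, so the step between them cannot be read, and the values now crowd at that limit: the limit of > 50000 nM in this assay, at which 3 of the 4 values shown sit.

From the compounds shown here alone, how far compound 3 and compound 4 lie beyond the limit stays open, and the two groups cannot be ranked against each other. Also open, going by these compounds, is whether a chlorine, a nitrile or a carboxylic acid on the phenyl ring at this nitrogen would give a number at all.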